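The source may hold more compounds than are shown below. What is called first, only, known or untested is meant among the compounds shown, and "the series" means these compounds.

Measured so far:
Compound 1, `Nc1nc(Cl)c2ncn(Cc3ccc(CCl)cc3)c2n1`, 10700 nM
Compound 2, `ClCc1cccc(Cn2cnc3c(Cl)nc(Cl)nc32)c1`, 4360 nM
Compound 3, `ClCc1ccc(Cn2cnc3c(Cl)nc(Cl)nc32)cc1`, 7240 nM

In a functional assay on SF-295 cells (Homo sapiens) for cytotoxicity, read by sulforhodamine B assay, with a stated time of 48 h (on this read-out higher numbers stand for weaker inhibition of growth and lower numbers for stronger inhibition of growth), compound 3 gives 7240 nM, and compound 1 gives 10700 nM. The two differ by one change, (amino in place of chloro on an aromatic carbon), and the step is a 1.5-fold higher number from compound 3 to compound 1 (0.17 log units; within the scatter). Compound 2 gives 4360 nM in this assay; the difference between its core and that of compound 3 is not broken down here. Compound 4, `Nc1nc(Cl)c2ncn(Cc3cccc(CCl)c3)c2n1`, has not yet been measured. It differs from compound 2 by amino in place of chloro on an aromatic carbon, the same change as that from compound 3 to compound 1. The step from compound 2 to compound 4 is therefore expected to be about a 1.5-fold higher number from compound 2 to compound 4 (0.17 log units; within the scatter), resting on the earlier step of a 1.5-fold higher number from compound 3 to compound 1 (0.17 log units; within the scatter). Compound 4 is expected to give around 6500 nM in this assay, most likely between 3000 nM and 14000 nM.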

Compound 4, concentration for 50% growth inhibition: 3380 nM
Compound 4: middle estimate off by 1.9-fold (0.28 log units), on the high side; low and high end bracket the measured number.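

In this assay, amino in place of chloro on an aromatic carbon brings a 1.3-fold lower number from compound 2 to compound 4 (0.11 log units; within the scatter). Set beside the earlier step, the change carries from one core to the other with no difference that can be told apart: the same change on two cores in this assay, a 1.5-fold higher number (0.17 log units; within the scatter) from compound 3 to compound 1 and a 1.3-fold lower number (0.11 log units; within the scatter) from compound 2 to compound 4, 1.9-fold (0.28 log units) apart, within the scatter of two such steps. This shows that on these two pairs the change leaves the number within the scatter, but it does not show that the change is without effect in general or that it would behave alike on any further core.

The compounds shown leave open whether a methylamino or a hydroxyl group on that same aromatic carbon would give a similar result. They also leave open how the amino for chloro change would behave on a third core.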